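A few compounds are considered here, and "the series" means these few. Any claim that something is new, unique, unknown or untested is made for them only; others in the source may bear on it.

In an ADME assay on WI-38 cells (Homo sapiens) for cytotoxicity, read by MTT assay, with a stated time of 72 h (on this read-out lower numbers stand for stronger inhibition and higher numbers for weaker inhibition), compound 1 (`O=C(CCc1cccc2c1B(O)OC2)Nc1nccs1`) gives > 100000 nM, which is a limit of the assay. Compound 3 (`C#Cc1cccc(NC(=O)CCc2cccc3c2B(O)OC3)c1`) gives > 100000 nM, which is also a limit. Among the compounds with values here, compound 2 (`O=C(CCc1cccc2c1B(O)OC2)Nc1ccc(I)cc1`) gives 49000 nM, the only actual number so far. The read-outs are crowded at one end: the limit of > 100000 nM in this assay, at which 2 of the 3 values shown sit. Compound 3 therefore stands at a limit, with no number from which to measure a step.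

The next structure is compound 4 (`O=C(CCc1cccc2c1B(O)OC2)Nc1cccc(-c2ccc(Cl)cc2)c1`), and the change from compound 3 is 4-chlorophenyl in place of ethynyl on an aromatic carbon. The new group sits on the same aromatic carbon, meta to a large group. Within the data shown here, the only measured step is an at least 2.0-fold lower number from compound 1 to compound 2 (0.30 log units; that floor lies within the scatter). It bears on this change only indirectly, since it concerns the group on the amide-type nitrogen and its size is known only as a floor. Compound 3 goes against reading that step as a general result of an aromatic ring at that nitrogen, as it stays at its limit.

In this assay, among the measured compounds shown here, a small move to a lower number is expected, resting on compound 2 at 49000 nM as the one halogen-bearing compound with a number, and it may not clear the scatter. The expected change is an at least 2.2-fold lower number from compound 3 to compound 4 (0.34 log units; beyond the scatter). For compound 4 the estimate is 45000 nM, with an expected range of 15000 nM to 100000 nM.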

Compound 4, half-maximal inhibitory concentration: 9800 nM
Compound 4: the middle estimate sits 4.6-fold (0.66 log units) above what was measured; the whole stated range lies above it.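

In this assay, within the data shown here, putting 4-chlorophenyl in place of ethynyl on this aromatic carbon gives an at least 10-fold lower number from compound 3 to compound 4 (1.00 log units; beyond the scatter), the only step so far printed as beyond the scatter. Among these compounds, the group on this carbon, meta to a large group, therefore moves the read-out clearly, which the earlier compounds could not show, since their one measured step concerned the group on the amide-type nitrogen and its floor lay within the scatter. The step remains a floor and not a size, because compound 3 stands at a limit of the assay: the limit of > 100000 nM in this assay, at which 2 of the 4 values shown sit.

The change brings 7 heavy atoms in place of 2, along with a ring and a chlorine, so the step cannot be assigned to any one of these, and an unsubstituted phenyl on the same carbon would begin to separate the ring from the chlorine. Also open, from the compounds shown here alone, is how the read-out responds to an amine or a carboxylic acid on this aromatic carbon, and whether any such group keeps the lower number seen here.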